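The source may report more compounds than this note shows. Statements on the series, on what has been measured and on what is new or still open speak of the compounds shown alone.

Measured compounds:
- compound 1 `C#CCn1cc(C(=O)NC(CC(=O)Nc2ccccc2)c2ccccc2)c(=O)c2cc(F)c(Cl)nc21` in a functional assay on A549 cells (Homo sapiens) for cytotoxicity, read by MTT assay, with a stated time of 72 h (a higher number here means a weaker inhibitor, a lower number a stronger inhibitor), gives > 10000 nM, which is a limit of the assay rather than a number.
- compound 2 `C#CCn1cc(C(=O)NC(CC(=O)NC2CCCCC2)c2ccccc2)c(=O)c2cc(F)c(Cl)nc21` gives > 10000 nM, again a limit.
- compound 3 `C#CCn1cc(C(=O)NC(CC(=O)Nc2ccccc2)c2ccccc2)c(=O)c2cccnc21` gives > 10000 nM, also a limit.

Compound 1 therefore stands at the limit, as do the other two compounds: the limit of > 10000 nM in this assay, at which 3 of the 3 values shown sit. Within the data shown here, the single comparable change, a step that the two limits leave unreadable from compound 1 to compound 2, cannot be sized from the two limits. The comparison of compound 1 with compound 3 likewise shows only two limits.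

Compound 4 `C#CCn1cc(C(=O)NC(CC(=O)Nc2ccccn2)c2ccccc2)c(=O)c2cc(F)c(Cl)nc21` differs from compound 1 by pyridin-2-yl in place of phenyl on an amide-type nitrogen. Among the measured compounds shown here, no measured step bears on this change with a readable size, and every value so far is a limit. The expectation for compound 4 in this assay is therefore that it too reaches no measurable number. Compound 4 is estimated at 20000 nM, with a range from 8000 nM to 100000 nM. This amounts to an expected step that the limit leaves unreadable from compound 1 to compound 4, most likely reported again only as a limit.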

Compound 4, half-maximal inhibitory concentration: > 10000 nM
Compound 4 was reported as a limit; the forecaster's own chance of this, stated with the estimate: 85%; the middle value does not contradict the limit.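

Compound 4, like compound 1 and compound 2, is reported only as a limit, so neither change to pyridin-2-yl can be given a size: the limit of > 10000 nM in this assay, at which 4 of the 4 values shown sit. Still open, on these data alone, is which structure, if any, would give a measurable number in this assay.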